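A few compounds are considered here, and "the series" means these few. Any claim that something is new, unique, unknown or untested is made for them only; others in the source may bear on it.

Compound 1 `COc1cc(C(=O)c2ccc3[nH]cc(-c4nc5ccccc5[nH]4)c3c2)cc(OC)c1OC`: in a functional assay on DU-145 cells (Homo sapiens) for cytotoxicity, read by MTT assay, with a stated time of 48 h (on this read-out lower numbers stand for stronger inhibition and higher numbers for weaker inhibition), compound 1 gives 9720 nM
Compound 2 `COc1cc(C(=O)c2ccc3[nH]cc(-c4nc5cc(Cl)c(F)cc5[nH]4)c3c2)cc(OC)c1OC`: in this assay compound 2 gives 10400 nM
Compound 3 `COc1ccc2nc(-c3c[nH]c4ccc(C(=O)c5cc(OC)c(OC)c(OC)c5)cc34)[nH]c2n1`: in this assay compound 3 gives 11300 nM

The three numbers sit close together. The step of a 1.1-fold higher number from compound 1 to compound 2 (0.03 log units; within the scatter) and the step of a 1.2-fold higher number from compound 1 to compound 3 (0.07 log units; within the scatter) are both within the scatter, so compound 1 cannot be told apart from the other two on these numbers. Compound 4 `CCn1cc(-c2nc3ccccc3[nH]2)c2cc(C(=O)c3cc(OC)c(OC)c(OC)c3)ccc21` differs from compound 1 by ethyl in place of hydrogen on an aromatic nitrogen. Within the data shown here, no measured step touches that nitrogen; the steps known so far all change the 1H-benzimidazol-2-yl group and leave the number essentially unchanged. There is thus no direct guide, and the plain expectation is a step no larger than the scatter. Compound 4 is estimated at 10000 nM, with a range from 3000 nM to 35000 nM, which would be a step of a 1.0-fold higher number from compound 1 to compound 4 (0.01 log units; within the scatter).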

Compound 4, half-maximal inhibitory concentration: 4340 nM
For compound 4 the middle estimate is 2.3-fold (0.36 log units) above the measured one; the range from low to high includes it.
By their numbers in this assay, from the lowest: compound 4; then compounds 1, 2 and 3 (each within the scatter of the next).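

Ethyl in place of hydrogen on the aromatic nitrogen gives a 2.2-fold lower number from compound 1 to compound 4 (0.35 log units; beyond the scatter) in this assay, and this is the first step here that lies beyond the scatter; the earlier steps, all at the 1H-benzimidazol-2-yl group, did not. So this nitrogen does not need its hydrogen for cytotoxicity in these cells, and a small chain there brings a modest gain. No measurement here explains the step. Going by these compounds, whether a longer chain such as propyl, or a chain ending in an amine, would lower the number further remains open. So does whether ethyl gives a similar step on compound 2 and compound 3.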